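Swapping an aryl group on two related cores

A few compounds are considered here, and "the series" means these few. Any claim that something is new, unique, unknown or untested is made for them only; others in the source may bear on it.

Compound 1 `COc1cccc(-c2ccc(COc3ccc4c(c3)[C@@H](O)CN(C)C4)cc2)c1` and compound 3 `COc1cccc(-c2cccc(COc3ccc4c(c3)[C@@H](O)CN(C)C4)c2)c1` share the same atoms joined in different ways; the difference between the two cores is not broken down here. In an ADME assay on Vero cells (Chlorocebus sabaeus) for cytotoxicity, read by sulforhodamine B assay, with a stated time of 72 h (on this read-out lower numbers stand for stronger inhibition and higher numbers for weaker inhibition), compound 1 gives 10800 nM, while compound 3 gives 24300 nM, a number beyond the usual scatter above that of compound 1.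

Compound 2 `CN1Cc2ccc(OCc3ccc(-c4ccc(Cl)cc4)cc3)cc2[C@@H](O)C1` differs from compound 1 by one change, (4-chlorophenyl in place of 3-methoxyphenyl on an aromatic carbon), and in this assay compound 2 gives 21700 nM. The step is a 2.0-fold higher number from compound 1 to compound 2 (0.30 log units; within the scatter), so within this pair the swap barely moves the read-out. Compound 2 and compound 3 also sit within the scatter of each other.

Compound 4 `CN1Cc2ccc(OCc3cccc(-c4ccc(Cl)cc4)c3)cc2[C@@H](O)C1` has not been measured. For the measured compounds named here, it arises from compound 3 by 4-chlorophenyl in place of 3-methoxyphenyl on an aromatic carbon, the same kind of change as the one from compound 1 to compound 2, though the place differs: on the core of compound 1 the group sits para to a large group, on the core of compound 3 meta to a large group. Going by the values given here, because the only measured example, a 2.0-fold higher number from compound 1 to compound 2 (0.30 log units; within the scatter), lies within the scatter, the expected step from compound 3 to compound 4 in this assay is estimated as a 1.4-fold higher number from compound 3 to compound 4 (0.16 log units; within the scatter), with the caveat that it rests on a single pair on a differently joined core. On that basis compound 4 is expected to give about 35000 nM, estimated to fall between 15000 nM and 80000 nM.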

Compound 4, half-maximal inhibitory concentration: 27300 nM
Compound 4: the middle estimate sits 1.3-fold (0.11 log units) above what was measured; measured number inside the range.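

In this assay, putting 4-chlorophenyl in place of 3-methoxyphenyl gives a 1.1-fold higher number from compound 3 to compound 4 (0.05 log units; within the scatter), a step too small to separate from the ordinary spread of repeated measurements. Set beside the same change on the other core, the two steps cannot be told apart: the same change on two cores in this assay, a 2.0-fold higher number (0.30 log units; within the scatter) from compound 1 to compound 2 and a 1.1-fold higher number (0.05 log units; within the scatter) from compound 3 to compound 4, 1.8-fold (0.25 log units) apart, within the scatter of two such steps. So, in this small set, the swap moves the read-out beyond the scatter on neither core, and nothing here suggests that the way the core is joined alters the outcome of the change; this does not prove that the change is without effect or that the two cores respond identically, as two small steps could hide a modest real difference, and two pairs say nothing about a third core.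

The compounds shown leave open whether a group much less like these two aryl groups, such as an amine or a carboxylic acid on the aromatic ring, or a simple longer chain in place of that ring, would shift the number beyond the scatter. They also leave open whether the swap would stay this small in any read-out other than this cytotoxicity measurement.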